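The source may hold more compounds than are shown below. What is called first, only, known or untested is meant among the compounds shown, and "the series" means these compounds.

Measured so far:
compound 1 `O=C(/C(=C\c1ccc(O)cc1O)SCc1ccc(Cl)cc1)c1ccc(Cl)cc1`, 50000 nM
compound 2 `O=C(/C(=C\c1ccccc1O)Sc1ccccc1Br)c1ccc(Br)cc1`, 50000 nM
compound 3 `O=C(/C(=C\c1c(O)cc(O)cc1O)SCc1ccc(Cl)cc1)c1ccc(Cl)cc1`, a limit only, > 100000 nM

In a functional assay on DU-145 cells (Homo sapiens) for inhibition, read by trypan blue exclusion, with a stated time of 96 h (a higher number here means a weaker inhibitor of growth, a lower number a stronger inhibitor of growth), compound 1 gives 50000 nM. Compound 2 gives 50000 nM in this assay, level with compound 1 at the digits shown. For compound 3 this assay reports only a limit, > 100000 nM; this is the limit of > 100000 nM in this assay, at which 1 of the 3 values shown sits. The change hydroxy in place of hydrogen on an aromatic carbon produced an at least 2.0-fold higher number from compound 1 to compound 3 (0.30 log units; that floor lies within the scatter). How the cores of compound 1 and compound 2 differ is not broken down here. Compound 4 `O=C(/C(=C\c1ccc(O)cc1O)Sc1ccccc1Br)c1ccc(Br)cc1` is not yet measured in this assay; it carries hydroxy in place of hydrogen on an aromatic carbon. This is the same kind of change as that made from compound 1 to compound 3, but the place differs: in compound 4 the hydroxy enters meta to a hydroxy group and para to a large group, whereas in compound 3 it entered ortho to a large group and meta to two hydroxy groups. Because the earlier change gave an at least 2.0-fold higher number from compound 1 to compound 3 (0.30 log units; that floor lies within the scatter), compound 4 is expected to show a 1.4-fold higher number from compound 2 to compound 4 (0.15 log units; within the scatter). Compound 4 is therefore estimated at 70000 nM, between 35000 nM and 150000 nM.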

Compound 4, concentration for 50% growth inhibition: 50000 nM
Compound 4: the middle estimate sits 1.4-fold (0.15 log units) above what was measured; the range from low to high includes it.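

In this assay, hydroxy in place of hydrogen on an aromatic carbon, here the change from 2-hydroxyphenyl to 2,4-dihydroxyphenyl, gives no change at the digits printed from compound 2 to compound 4 (within the scatter). Set beside the earlier case, the two steps read: the same change on two cores in this assay, an at least 2.0-fold higher number (0.30 log units; that floor lies within the scatter) from compound 1 to compound 3 and no change at the digits printed (within the scatter) from compound 2 to compound 4; the limit leaves it open whether they differ. Compound 3 has only a limit, > 100000 nM, and the two steps show neither that this change carries from one core to another nor that it does not.

The compounds shown leave open whether another group on the aromatic ring, such as an amine or a carboxylic acid in place of the hydroxy, would give a different value in this assay. They also leave open what a third hydroxy, as in compound 3, would do on the core of compound 2.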